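Moving a fluorine on the benzyl group of the shared core

This account rests on a few compounds, and the source may have more. Where it says the series, first, only, none or still open, it means among the compounds named here.

Measured so far:
compound 1, `CC1(C)c2[nH]nc(NC(=O)c3ccccc3)c2CN1Cc1cccc(F)c1F`: 200 nM
compound 2, `CC1(C)c2[nH]nc(NC(=O)c3ccccc3)c2CN1Cc1cc(F)ccc1F`: 480 nM

Both compounds were tested in an assay on Sf21 cells for inhibition of high affinity nerve growth factor receptor (Homo sapiens), read by HTRF, with a stated time of 30 min, in the presence of a further agent that is not named here; on this read-out higher numbers stand for weaker inhibition and lower numbers for stronger inhibition. For the measured compounds named here, compound 2 stands as the higher of the two numbers; its only neighbour is compound 1, and the step of a 2.4-fold higher number from compound 1 to compound 2 (0.38 log units; beyond the scatter) separates them. Compound 3, `CC1(C)c2[nH]nc(NC(=O)c3ccccc3)c2CN1Cc1c(F)cccc1F`, has not yet been measured. It differs from compound 2 by 2,6-difluorophenyl in place of 2,5-difluorophenyl on a saturated chain carbon bound to an amine nitrogen in a ring; the two compounds have the same atoms, joined differently.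

Going by the values given here, no measured step involves the 2,6-difluorophenyl group, so the only guide is the step of a 2.4-fold higher number from compound 1 to compound 2 (0.38 log units; beyond the scatter), which shows that shifting one fluorine on this ring changes the number modestly, beyond the scatter, but not by a large amount. On that basis compound 3 is expected to land within a similar distance of compound 2, in a direction the data cannot fix, so the expected step of a 1.6-fold lower number from compound 2 to compound 3 (0.20 log units; within the scatter) is small. Compound 3 is estimated at 300 nM, with a range from 100 nM to 900 nM.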

Compound 3, half-maximal inhibitory concentration: 520 nM
For compound 3 the middle estimate is 1.7-fold (0.24 log units) below the measured one; low and high end bracket the measured number.
By their numbers in this assay, from the lowest: compound 1; then compounds 2 and 3 (each within the scatter of the next).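

In this assay, a 1.1-fold higher number from compound 2 to compound 3 (0.03 log units; within the scatter), so at this position on a saturated chain carbon bound to an amine nitrogen in a ring, 2,6-difluorophenyl and 2,5-difluorophenyl cannot be told apart, and the earlier finding that relocating a fluorine changes the number does not hold for every such change. With a 2.6-fold higher number from compound 1 to compound 3 (0.41 log units; beyond the scatter), which lies beyond the scatter, compound 1 now stands apart from both of the others, making 2,3-difluorophenyl the strongest of these three arrangements, while compound 2 and compound 3 form a single level. No measurement shown accounts for why the 2,3-difluorophenyl group differs from the other two.

The compounds shown leave open how a plain phenyl without fluorine, a chlorophenyl or a pyridine ring would compare with these difluorophenyl groups at the same place. They also leave open whether the advantage of 2,3-difluorophenyl would persist if the benzoyl group on the amide of the shared core were replaced by a smaller acetyl group.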